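Anilino for benzyl on the amide of compound 2

The source may report more compounds than this note shows. Statements on the series, on what has been measured and on what is new or still open speak of the compounds shown alone.

Measured so far, in an in vitro assay on CHOk1 cells with adenosine receptor A1 (Homo sapiens) as the target; on this read-out higher numbers stand for an effect only at larger amounts of compound and lower numbers for an effect already at smaller amounts:
Compound 1 `Nc1sc2c(c1C(=O)NCc1ccccc1)CCN(Cc1ccccc1)C2` gives 13100 nM.
Compound 2 `CN1CCc2c(sc(N)c2C(=O)NCc2ccccc2)C1` gives 12000 nM.
Compound 3 `CN1CCc2c(sc(N)c2C(=O)NCc2cccc(Cl)c2)C1` gives 13200 nM.

The three numbers sit close together. Within the data shown here, compound 2 has the lowest of them, but its steps to the others, a 1.1-fold lower number from compound 1 to compound 2 (0.04 log units; within the scatter) and a 1.1-fold higher number from compound 2 to compound 3 (0.04 log units; within the scatter), both lie within the scatter, so no compound can be set apart from the rest on this evidence.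

Compound 4 `CN1CCc2c(sc(N)c2C(=O)NNc2ccccc2)C1` differs from compound 2 in one place: anilino in place of benzyl on an amide-type nitrogen. Neither of the measured steps touches this nitrogen. Among the measured compounds shown here, the change at the ring nitrogen and the change on the aromatic ring each left this assay essentially unmoved, and no measured pair shows what replacing a benzyl by an anilino on the amide nitrogen does. With nothing in the data pointing one way or the other, the expectation for compound 4 is a number in the same region as compound 2, with a wide range to cover the absence of any bearing step.

Compound 4 is therefore estimated at 14000 nM, between 4500 nM and 45000 nM. This estimate amounts to a 1.2-fold higher number from compound 2 to compound 4 (0.07 log units; within the scatter), which is expected to stay within the scatter.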

Compound 4, half-maximal effective concentration: 11500 nM
Compound 4: middle estimate off by 1.2-fold (0.09 log units), on the high side, within the range that was stated.
By their numbers in this assay, from the lowest: compounds 4, 2, 1 and 3 (each within the scatter of the next).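

In this assay, among these compounds, the replacement of benzyl by anilino on the amide-type nitrogen gives a 1.0-fold lower number from compound 2 to compound 4 (0.02 log units; within the scatter), which is the first reading at this position, since the earlier steps changed other parts of the molecule. The exchange keeps the size of the group and its six-membered aromatic ring while adding the hydrogen-bond donor and acceptor counted for anilino, and on this evidence that particular change does not separate compound 4 from compound 2. No measured evidence accounts for this result or says what the unchanged number reflects.

What remains open is whether this position can move the number at all, as every group on the amide-type nitrogen shown here carries a six-membered aromatic ring of carbon only and every step so far lies within the scatter. A plain methyl, a longer alkyl chain or a chain ending in a carboxylic acid on this nitrogen would test that, and the compounds shown do not say whether any of these would give a number outside the narrow region they occupy.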